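Aryl-substituent effects in a trimethoxyphenyl beta-lactam antiproliferative series

A few compounds are considered here, and "the series" means these few. Any claim that something is new, unique, unknown or untested is made for them only; others in the source may bear on it.

Measured compounds:
compound 1 `COc1cc(N2C(=O)[C@H](Oc3ccccc3)[C@H]2c2ccc(C#N)cc2)cc(OC)c1OC`, 168000 nM
compound 2 `COc1cc(N2C(=O)[C@@H](Oc3ccccc3)[C@H]2c2cccc([N+](=O)[O-])c2)cc(OC)c1OC`, 30000 nM
compound 3 `COc1ccc([C@@H]2[C@@H](Oc3ccccc3)C(=O)N2c2cc(OC)c(OC)c(OC)c2)cc1N`, 13 nM

All three compounds share the same core and differ only in the aryl group on a saturated ring carbon. Among the measured compounds shown here, in a functional assay on MCF7 cells (Homo sapiens) for antiproliferative activity, read by MTT assay, with stated times of 24 h and 72 h (on this read-out higher numbers stand for weaker inhibition and lower numbers for stronger inhibition), compound 1 gives 168000 nM and compound 3 gives 13 nM; the step between them, a 13000-fold lower number from compound 1 to compound 3 (4.11 log units; beyond the scatter), is the only single-point step available. For the measured compounds named here, compound 2 stands second highest of the three numbers, above compound 3 by a wide margin and below compound 1, with no single-point step defined against either.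

Compound 4 `COc1cc(N2C(=O)[C@@H](Oc3ccccc3)[C@H]2c2cccc(N)c2)cc(OC)c1OC` is not yet measured. It differs from compound 2 by amino in place of nitro on an aromatic carbon. The step from compound 1 to compound 3 bears on this, since it also introduces an amino group onto the aryl ring together with a methoxy group, and it was very large in the direction of stronger inhibition. Compound 4 carries the amino group alone, so a large step in the same direction is expected, though less extreme. Compound 4 is estimated at 200 nM, range 20 nM to 2000 nM, corresponding to an expected step of a 150-fold lower number from compound 2 to compound 4 (2.18 log units; beyond the scatter).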

Compound 4, half-maximal inhibitory concentration: 17000 nM
Estimate against measurement, compound 4: 85-fold (1.93 log units) below; measured number above the stated range.
By their numbers in this assay, from the lowest: compound 3; then compounds 4 and 2 (each within the scatter of the next); then compound 1.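

In this assay the change from 3-nitrophenyl to 3-aminophenyl gives a 1.8-fold lower number from compound 2 to compound 4 (0.25 log units; within the scatter) and so leaves the number unmoved at this position on the shared core. The amino group alone therefore does not reproduce the size of a 13000-fold lower number from compound 1 to compound 3 (4.11 log units; beyond the scatter) on this aryl ring, and that step, which brings in a methoxy group with the amino group and removes a nitrile, cannot be credited to the amino group by itself. Nitro and amino, on an aromatic carbon meta to a large group, cannot be told apart in this read-out. Nothing shown gives a reason for this result.

Still open, as far as these compounds go, is what the methoxy group contributes, alone or with the amino group. A hydroxyl or a dimethylamino group on the aryl ring would test how specific the amino group is in that setting.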